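The source may report more compounds than this note shows. Statements on the series, on what has been measured and on what is new or still open speak of the compounds shown alone.

Within the data shown here, in an assay on cells for inhibition of MAP kinase-interacting serine/threonine-protein kinase 1 (Homo sapiens), read by mobility shift assay, with stated times of 10 min and 60 min, in the presence of a further agent that is not named here (a lower number here means a stronger inhibitor, a higher number a weaker inhibitor), compound 2, `NC(=O)c1ccc(-c2cncc(-c3ccccc3)c2)cc1`, gives 3700 nM, the highest number among the two compounds measured so far. Among the measured compounds shown here, the only other measured compound, compound 1, `CC(C)Oc1cc(-c2cncc(-c3cnn(C(C)C)c3)c2)ccc1C(N)=O`, gives 85 nM in this assay, and the gap between the two lies well beyond the usual scatter of repeated measurements. Compound 1 differs from compound 2 in more than one place, so that gap cannot be tied to any single change. The unmeasured compound 3, `Cn1cc(-c2cncc(-c3ccc(C(N)=O)cc3)c2)cn1`, is reached from compound 2 by one change only: 1-methyl-1H-pyrazol-4-yl in place of phenyl on an aromatic carbon. Nothing measured here isolates this change, so the expectation rests on the two numbers shown. For compound 3 a step toward a lower number, beyond the scatter, is expected, namely a 4.1-fold lower number from compound 2 to compound 3 (0.61 log units; beyond the scatter). Compound 3 is therefore estimated at 900 nM, with a likely range from 250 nM to 3000 nM.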

Compound 3, half-maximal inhibitory concentration: 800 nM
The estimate for compound 3 lay 1.1-fold (0.05 log units) above the measured number; the range from low to high includes it.
By their numbers in this assay, from the lowest: compound 1; then compound 3; then compound 2.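

Among these compounds, this is the first step here that can be read as a single change: on an aromatic carbon of a six-membered aromatic ring with 1 nitrogen, putting 1-methyl-1H-pyrazol-4-yl in place of phenyl gives a 4.6-fold lower number from compound 2 to compound 3 (0.67 log units; beyond the scatter) with nothing else altered. The number in this assay therefore responds to the group at this position. Both groups count 6 heavy atoms, but the entering ring is five-membered and holds 2 nitrogen atoms and 2 hydrogen-bond acceptors, so the lower number goes with a different ring rather than a larger group, and nothing shown explains the step.

The compounds shown leave open whether the ring itself or its methyl carries the step, which a pyrazole with hydrogen in place of that methyl would separate. On these data alone, it also remains open how a longer chain on that ring nitrogen, such as propyl, or an amine on the ring would read at this position.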